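The compounds below may be only part of what the source reports. "The series", "measured", "known", "first", "only" and "open" are said of these compounds alone.

In a functional assay on the whole organism (strain Kunming) with Mus musculus as the target, with a stated time of 0.5 h (on this read-out higher numbers stand for an effect only at larger amounts of compound and lower numbers for an effect already at smaller amounts), compound 1 (`COc1ccccc1/C=C/C(=O)OC/C=C/c1cc(OC)c(OC)cc1OC`) gives 240 mg/kg and sits level with compound 2 (`COc1cc(OC)c(OC)cc1/C=C/COC(=O)/C=C/c1ccc(OC)c(OC)c1`) at 173 mg/kg and compound 3 (`COc1cc(OC)c(OC)cc1/C=C/COC(=O)/C=C/c1c(OC)ccc(OC)c1OC`) at 212 mg/kg as all three numbers lie within the usual scatter. Compound 4 (`COc1cc(OC)c(OC)cc1/C=C/COC(=O)/C=C/c1ccccc1Cl`) differs from compound 1 in one place: chloro in place of methoxy on an aromatic carbon (2-methoxyphenyl to 2-chlorophenyl). One measured step changes this same aryl group. Going by the values given here, because a 1.4-fold lower number from compound 1 to compound 2 (0.14 log units; within the scatter) stayed within the scatter, no step beyond the scatter is expected here, in either direction, although no measured compound carries chloro. The estimated step of a 1.2-fold lower number from compound 1 to compound 4 (0.08 log units; within the scatter) is accordingly expected to be small. Compound 4 is estimated at 200 mg/kg (expected range 110 mg/kg to 360 mg/kg).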

Compound 4, dose for half-maximal effect: 150 mg/kg
The estimate for compound 4 lay 1.3-fold (0.12 log units) above the measured number, within the range that was stated.
By their numbers in this assay, from the lowest: compounds 4, 2, 3 and 1 (each within the scatter of the next).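

In this assay, chloro in place of methoxy gives a 1.6-fold lower number from compound 1 to compound 4 (0.20 log units; within the scatter). Replacing the 3,4-dimethoxyphenyl group with 2-chlorophenyl gives a 1.2-fold lower number from compound 2 to compound 4 (0.06 log units; within the scatter), so at this place on the shared core, a group without methoxy still leaves the number level with those of the methoxy-bearing compounds. Nothing available offers an explanation for this. Going by these compounds, whether an amine or a carboxylic acid on this aromatic carbon would move the number beyond the scatter stays open. So does the effect of chloro on any other aromatic carbon of this ring.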